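Lengthening a hydroxyalkyl chain on a shared core

A few compounds are considered here, and "the series" means these few. Any claim that something is new, unique, unknown or untested is made for them only; others in the source may bear on it.

Compound 1 `O=c1cc(Cn2cc(C3CC3)nn2)c2ccc(O)cc2o1` and compound 2 `O=c1cc(Cn2cc(CCCO)nn2)c2ccc(O)cc2o1` share one core and differ in a single group. In a functional assay on HepG2 cells (Homo sapiens) for inhibition, read by MTT assay, with a stated time of 72 h (a higher number here means a weaker inhibitor, a lower number a stronger inhibitor), compound 1 gives > 100000 nM, which is a limit of the assay rather than a number. In this assay compound 2 likewise gives > 100000 nM, again only a limit. Going by the values given here, the one measured step, a step that the two limits leave unreadable from compound 1 to compound 2, therefore cannot be read for size, since both values sit at the limit of > 100000 nM in this assay, at which 2 of the 2 values shown sit. Where compound 2 stands is thus known only as a limit.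

Compound 3 `O=c1cc(Cn2cc(CCCCO)nn2)c2ccc(O)cc2o1` is not yet measured. It differs from compound 2 by hydroxymethyl in place of hydroxy on a saturated chain carbon, three bonds along the chain from an aromatic carbon, which in effect lengthens 3-hydroxypropyl to 4-hydroxybutyl. Among the compounds with values here, no measured step bears directly on this change; the only step available, from compound 1 to compound 2, is unreadable. With both measured values at the limit, no shift beyond the scatter can be predicted in either direction, and the expectation is that compound 3 will also come back as a limit. For compound 3 the step that the limit leaves unreadable from compound 2 to compound 3 is estimated as essentially none. Compound 3 is estimated at 150000 nM, with a range from 50000 nM to 500000 nM.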

Compound 3, half-maximal inhibitory concentration: > 100000 nM
Compound 3: a limit, no number; the forecaster's own chance of this, stated with the estimate: 85%; the middle value lies beyond the limit too.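

In this assay compound 3 gives > 100000 nM, again a limit and not a number. No step among compound 1, compound 2 and compound 3 can be read for size, since all the values sit at one limit: the limit of > 100000 nM in this assay, at which 3 of the 3 values shown sit.

The compounds shown leave open how strong each one really is, and whether cyclopropyl, 3-hydroxypropyl or 4-hydroxybutyl makes any difference.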